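Swapping Trifluoromethyl for Fluoro: What to Expect of Compound 4

This account rests on a few compounds, and the source may have more. Where it says the series, first, only, none or still open, it means among the compounds named here.

Of the compounds shown here, three have so far been measured in an ADME assay on the whole organism with Oryza sativa as the target, tested at 10 uM; on this read-out higher numbers stand for a weaker effect at the one concentration tested and lower numbers for a stronger effect. Compound 1 `Cc1cccc(NC(=O)N[C@H](C)c2ccccc2)c1` gives 47%, compound 2 `C[C@@H](NC(=O)Nc1cccc(C(F)(F)F)c1)c1ccccc1` gives 70%, and compound 3 `C[C@H](NC(=O)Nc1cccc(C(F)(F)F)c1)c1ccccc1` gives 92%. Compound 2 therefore stands second highest of the three: a number 23 percentage points higher from compound 1 to compound 2 (beyond the scatter), and a number 22 percentage points higher from compound 2 to compound 3 (beyond the scatter), this last step arising only from the fact that compounds 2 and 3 differ only in the configuration as drawn. The unmeasured compound 4 `C[C@@H](NC(=O)Nc1cccc(F)c1)c1ccccc1` differs from compound 2 by fluoro in place of trifluoromethyl on an aromatic carbon. The step from compound 1 to compound 2 is the one that bears on this change, since it also altered the same group on the same aromatic carbon and gave a modest rise in the number. Going part of the way back, a modest drop is expected in this assay. Compound 4 is therefore estimated at 55%, within 35% to 75%, which is expected to be a number 15 percentage points lower from compound 2 to compound 4 (beyond the scatter).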

Compound 4, a percentage reported as activity, at one concentration (the size of the read-out at that concentration, not a potency): 84%
Compound 4: middle estimate off by 29 percentage points, on the low side, outside the stated range (above it).
By their numbers in this assay, from the lowest: compound 1; then compound 2; then compounds 4 and 3 (each within the scatter of the next).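

Replacing trifluoromethyl with the smaller fluoro does not move the result back towards the methyl compound in this assay: the change gives a number 14 percentage points higher from compound 2 to compound 4 (beyond the scatter) and, measured against methyl, a number 37 percentage points higher from compound 1 to compound 4 (beyond the scatter) on the same aromatic carbon. The number therefore does not simply follow group size here, as fluoro, with 1 heavy atom, ends higher than trifluoromethyl, with 4. How an amine or a methoxy group would read at this place remains open, as does whether fluoro behaves alike with the stereocentre drawn S. Nothing shown explains why fluoro and trifluoromethyl fall in this order.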